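Swapping Fluoro for Cyano on the Sulfonyl Aryl Ring

The source may hold more compounds than are shown below. What is called first, only, known or untested is meant among the compounds shown, and "the series" means these compounds.

Compound 1 `CC1CCN(c2c(S(=O)(=O)c3ccc(F)cc3)cnc3ccc(F)cc23)CC1` gives 87% in an assay on isolated protein for displacement of a labelled ligand from metabotropic glutamate receptor 5 (Homo sapiens), with a stated time of 60 min, tested at 1 uM; on this read-out lower numbers stand for less inhibition and higher numbers for more inhibition at the one concentration tested (going by the name of the read-out). Among the three measured compounds it stands second highest, the nearest being compound 2 `CC1CCN(c2c(S(=O)(=O)c3ccc(F)cc3)cnc3ccc(Cl)cc23)CC1` with 89% and the furthest compound 3 `COc1ccc2ncc(S(=O)(=O)c3ccc(F)cc3)c(N3CCC(C)CC3)c2c1` with 27%. The step of a number 2 percentage points higher from compound 1 to compound 2 (within the scatter) lies within the scatter, whereas the step of a number 60 percentage points lower from compound 1 to compound 3 (beyond the scatter) is large, as is a number 62 percentage points lower from compound 2 to compound 3 (beyond the scatter).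

Compound 4 `CC1CCN(c2c(S(=O)(=O)c3ccc(C#N)cc3)cnc3ccc(F)cc23)CC1` is compound 1 with one change: cyano in place of fluoro on an aromatic carbon. For the measured compounds named here, the measured steps all concern a substituent on the shared core, where a methoxy in place of a halogen costs much; none of them touches the 4-fluorophenyl ring attached through the sulfonyl group, so no step directly informs this change. As far as these compounds go, compound 1 and compound 2 show that the core halogens both keep the inhibition high, but what a cyano group on the other ring does is unknown. A moderate loss or no change beyond the scatter is therefore expected, giving an estimated step of a number 15 percentage points lower from compound 1 to compound 4 (beyond the scatter) for compound 4. Compound 4 is estimated at 72%, within a range from 40% to 95%.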

Compound 4, a percentage reported as inhibition, at one concentration (the size of the read-out at that concentration, not a potency): 75%
For compound 4 the middle estimate is 3 percentage points below the measured one; low and high end bracket the measured number.
By their numbers in this assay, from the lowest: compound 3; then compound 4; then compounds 1 and 2 (each within the scatter of the next).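

The change from 4-fluorophenyl to 4-cyanophenyl is the first one shown on the ring attached through the sulfonyl group, and in this assay it gives a number 12 percentage points lower from compound 1 to compound 4 (beyond the scatter). This is a modest but real loss, so this position does respond to its substituent, yet a nitrile there still leaves compound 4 at 75%. Nothing shown explains why the number falls with this swap.

The compounds shown leave open how an amine or a carboxylic acid on this ring would read, and whether the ring needs a substituent at all, which a plain phenyl ring would show. Also open, as far as these compounds go, is whether the same swap would cost as much with the chloro group of compound 2 on the shared core.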